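Cytotoxicity of Trifluorophenyl Analogue Compared with Fluorophenyl Parent

The source may hold more compounds than are shown below. What is called first, only, known or untested is meant among the compounds shown, and "the series" means these compounds.

Measured compounds:
compound 1, `COc1cccc2c1c(C(=O)/C=C(\O)C(=O)O)cn2Cc1cccc(F)c1`: 65800 nM
compound 2, `CCOC(=O)/C(O)=C/C(=O)c1cn(Cc2ccc(F)cc2F)c2cccc(OC)c12`: 65500 nM
compound 3, `CCOC(=O)/C(O)=C/C(=O)c1cn(Cc2ccccc2F)c2cccc(OC)c12`: 63300 nM

In an ADME assay on MT4 cells (Homo sapiens) for cytotoxicity, read by MTT assay (on this read-out higher numbers stand for lower toxicity in this test and lower numbers for higher toxicity in this test), compound 1 gives the highest of the three numbers, yet its gaps to compound 2 and compound 3 both lie within the scatter, so the three stand together. Among the compounds with values here, the only single-point step among them, a 1.0-fold lower number from compound 2 to compound 3 (0.01 log units; within the scatter), concerns hydrogen in place of fluoro on an aromatic carbon and is itself within the scatter.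

Compound 4, `COc1cccc2c1c(C(=O)/C=C(\O)C(=O)O)cn2Cc1cc(F)c(F)c(F)c1`, differs from compound 1 by 3,4,5-trifluorophenyl in place of 3-fluorophenyl on a saturated chain carbon bound to an aromatic nitrogen. Within the data shown here, that step also adds fluoro to the aromatic ring, and the one comparable change, from compound 2 to compound 3, showed nothing beyond the scatter, so no step beyond the scatter is expected here either, a 1.1-fold lower number from compound 1 to compound 4 (0.03 log units; within the scatter). Compound 4 is therefore estimated at 62000 nM, within 35000 nM to 110000 nM.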

Compound 4, half-maximal cytotoxic concentration: 23300 nM
For compound 4 the middle estimate is 2.7-fold (0.43 log units) above the measured one, outside the stated range (below it).
By their numbers in this assay, from the lowest: compound 4; then compounds 3, 2 and 1 (each within the scatter of the next).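

In this assay, 3,4,5-trifluorophenyl in place of 3-fluorophenyl on a saturated chain carbon bound to an aromatic nitrogen gave a 2.8-fold lower number from compound 1 to compound 4 (0.45 log units; beyond the scatter), so the fluoro pattern at this position can shift the number, although only modestly. The earlier fluoro change, a 1.0-fold lower number from compound 2 to compound 3 (0.01 log units; within the scatter), had shown no such shift. Nothing available explains the difference between the two steps. As far as these compounds go, it remains open whether the same change would give a similar step in the ethyl ester series of compound 2 and compound 3, and how chloro on this ring or a longer chain at this position would read.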